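This account rests on a few compounds, and the source may have more. Where it says the series, first, only, none or still open, it means among the compounds named here.

Measured in a functional assay on the whole organism with Scenedesmus acutus as the target; on this read-out lower numbers stand for stronger inhibition and higher numbers for weaker inhibition:
- compound 1 `O=C(O)c1cc(N2C(=O)C3=C(CCCC3)C2=O)c(F)cc1Cl`: 759 nM
- compound 2 `CCOC(=O)c1cc(N2C(=O)C3=C(CCCC3)C2=O)c(F)cc1Cl`: 100 nM

Compound 2 holds the lower of the two numbers in this assay. Compound 3 `CCCOC(=O)c1cc(N2C(=O)C3=C(CCCC3)C2=O)c(F)cc1Cl` differs from it by methyl in place of hydrogen on a saturated chain carbon, two bonds along the chain from an oxygen next to a carbonyl group, which reads as ethyl to propyl. For the measured compounds named here, only one measured step bears on this: a 7.6-fold lower number from compound 1 to compound 2 (0.88 log units; beyond the scatter), with ethyl in place of hydrogen on an oxygen next to a carbonyl group. Going by the values given here, that is a different and larger change, and no measured step lengthens the chain, so no step beyond the scatter is expected in this assay. The expected step is a 1.1-fold higher number from compound 2 to compound 3 (0.04 log units; within the scatter). The estimate for compound 3 is 110 nM, with an expected range of 45 nM to 260 nM.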

Compound 3, half-maximal inhibitory concentration: 89.1 nM
Estimate against measurement, compound 3: 1.2-fold (0.09 log units) above; low and high end bracket the measured number.
By their numbers in this assay, from the lowest: compounds 3 and 2 (each within the scatter of the next); then compound 1.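

In this assay methyl in place of hydrogen on a saturated chain carbon, two bonds along the chain from an oxygen next to a carbonyl group, gives a 1.1-fold lower number from compound 2 to compound 3 (0.05 log units; within the scatter) and so ethyl to propyl is a change this read-out does not resolve. Propyl in place of hydrogen on that oxygen gives an 8.5-fold lower number from compound 1 to compound 3 (0.93 log units; beyond the scatter) and so the gap first seen with ethyl holds for a second chain. Nothing available explains either step. On these data alone, whether a longer chain such as butyl, a branched chain such as isopropyl, or an amide in place of this group stays at the level of compound 3 remains open.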